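The source may report more compounds than this note shows. Statements on the series, on what has been measured and on what is new or still open speak of the compounds shown alone.

Measured so far in an assay for inhibition of Fatty-acid amide hydrolase 1 (Rattus norvegicus); on this read-out higher numbers stand for weaker inhibition and lower numbers for stronger inhibition:
- compound 1, `O=C(CCCCC#Cc1ccccn1)c1ncc(-c2ccccn2)o1`: 280 nM
- compound 2, `O=C(CCCCC#Cc1cccnc1)c1ncc(-c2ccccn2)o1`: 300 nM
- compound 3, `O=C(CCCCCCc1cccnc1)c1ncc(-c2ccccn2)o1`: 32 nM

Compound 3 gives the lowest number of the three. The steps to it are an 8.8-fold lower number from compound 1 to compound 3 (0.94 log units; beyond the scatter) and a 9.4-fold lower number from compound 2 to compound 3 (0.97 log units; beyond the scatter), both beyond the scatter, so compound 3 stands apart from compound 1 and compound 2 on this read-out. The two values of compound 1 and compound 2 lie within the scatter of each other, as the step of a 1.1-fold higher number from compound 1 to compound 2 (0.03 log units; within the scatter) shows.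

The next compound, compound 4, is `COc1ccc(CCCCCCC(=O)c2ncc(-c3ccccn3)o2)cc1`. The change from compound 3 is 4-methoxyphenyl in place of pyridin-3-yl on a saturated chain carbon, six bonds along the chain from a carbonyl carbon. For the measured compounds named here, the only measured swap of one aromatic group for another is the step from compound 1 to compound 2, which stayed within the scatter; it concerns a different pair of groups and a different attachment, so it bears on the present step only loosely. Going by the values given here, no measured step covers an exchange of a pyridinyl ring for a 4-methoxyphenyl ring. The saturated chain of compound 3, which is kept in compound 4, is where the measured steps placed the gain.

With the chain held and only the terminal ring changed, the expected step is a 1.1-fold lower number from compound 3 to compound 4 (0.03 log units; within the scatter), that is, no step beyond the scatter in either direction. Compound 4 is therefore estimated at 30 nM, with a range from 8 nM to 120 nM.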

Compound 4, inhibition constant: 6.2 nM
For compound 4 the middle estimate is 4.8-fold (0.68 log units) above the measured one, outside the stated range (below it).
By their numbers in this assay, from the lowest: compound 4; then compound 3; then compounds 1 and 2 (each within the scatter of the next).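

In this assay, a step of a 5.2-fold lower number from compound 3 to compound 4 (0.71 log units; beyond the scatter) shows that the terminal ring on the saturated chain, six bonds along the chain from a carbonyl carbon, can shift the number on its own while the chain stays the same. The earlier change of terminal ring, a 1.1-fold higher number from compound 1 to compound 2 (0.03 log units; within the scatter), stayed within the scatter, and it was made on the triple-bonded chain, so until now only the change of chain had produced a step beyond the scatter. For the compounds shown here, this step is the first beyond the scatter to come from the terminal ring, though it replaces the ring and adds the methoxy group in one move, and no measured evidence on hand bears on the result.

Still open, going by these compounds, is how much of the step belongs to the ring and how much to the methoxy group, which a plain phenyl ring at the chain end would help to separate. Also open, on these data alone, is whether 4-methoxyphenyl would give a similar step on the triple-bonded chain of compound 1 and compound 2, or on a longer chain.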